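This account rests on a few compounds, and the source may have more. Where it says the series, first, only, none or still open, it means among the compounds named here.

Compound 1 `CCn1c(C(=O)NCCNC(=O)OC(C)(C)C)ccc1C(CC)(CC)c1ccc(OCS(=O)(=O)c2ccccc2)c(C)c1` gives > 50000 nM in a functional assay on MCF7 cells (Homo sapiens) for antiproliferative activity, read by MTT assay, with a stated time of 24 h; on this read-out higher numbers stand for weaker inhibition and lower numbers for stronger inhibition.
Compound 2 `CCn1c(C(=O)N[C@H](C)CO)ccc1C(CC)(CC)c1ccc(OCS(=O)(=O)c2ccccc2)c(C)c1` gives 10600 nM.
Compound 3 `CCn1c(C(=O)N[C@@H](CO)CCCO)ccc1C(CC)(CC)c1ccc(OCS(=O)(=O)c2ccccc2)c(C)c1` gives 29600 nM.

The value of compound 1 is a limit of the assay, not a measured number, so compound 1 stands only at the weak end of the numbers shown (the limit of > 50000 nM in this assay, at which 1 of the 3 values shown sits). Compound 4 `CCn1c(C(=O)N[C@H](CC(=O)O)C(=O)O)ccc1C(CC)(CC)c1ccc(OCS(=O)(=O)c2ccccc2)c(C)c1` differs from compound 1 at the amide-type nitrogen: 1,2-dicarboxyethyl in place of 2-((tert-butoxycarbonyl)amino)ethyl on an amide-type nitrogen. Among the measured compounds shown here, two measured steps bear on this change, since both also swap out the 2-((tert-butoxycarbonyl)amino)ethyl group for a smaller, oxygen-bearing group on the same nitrogen: an at least 4.7-fold lower number from compound 1 to compound 2 (0.67 log units; beyond the scatter), and an at least 1.6-fold lower number from compound 1 to compound 3 (0.22 log units; that floor lies within the scatter), the second of which only has a floor within the scatter. A third step, a 2.8-fold higher number from compound 2 to compound 3 (0.45 log units; beyond the scatter), shows that adding a further hydroxyl-bearing chain pushes the number back up. For compound 4 a lower number is therefore expected, but not a large step, given that compound 3 reaches only 29600 nM. The estimate for compound 4 is 30000 nM, between 9000 nM and 60000 nM, an expected step of an at least 1.6-fold lower number from compound 1 to compound 4 (0.22 log units; that floor lies within the scatter).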

Compound 4, half-maximal inhibitory concentration: > 50000 nM
Compound 4: a limit, no number; the forecaster's own chance of this, stated with the estimate: 40%; middle value at least 1.6-fold (0.22 log units) from the limit.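

In this assay compound 4 gives > 50000 nM, a limit of the assay and not a number, so the step from compound 1, itself at a limit, cannot be read. Among the compounds shown here, a smaller group on the amide-type nitrogen therefore does not always bring the number down, as the earlier compounds alone might have suggested: 1,2-dicarboxyethyl in place of 1-(hydroxymethyl)ethyl gives an at least 4.7-fold higher number from compound 2 to compound 4 (0.67 log units; beyond the scatter), while the comparison with the longer diol-bearing group gives an at least 1.6-fold higher number from compound 3 to compound 4 (0.22 log units; that floor lies within the scatter). Two very different groups now leave compounds at the same ceiling: the limit of > 50000 nM in this assay, at which 2 of the 4 values shown sit.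

From the compounds shown here alone, how far above that ceiling compound 4 lies remains open. Also open, going by these compounds, is how a group with a single carboxylic acid, or an amine, on this nitrogen would read, which would show whether one acid group is enough to lose the activity.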